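Trifluoromethyl for chloro on the benzyl ring

The source may hold more compounds than are shown below. What is called first, only, known or untested is meant among the compounds shown, and "the series" means these compounds.

Two compounds of the series carry measurements. Within the data shown here, compound 1 `O=C(NCc1cn(Cc2ccc(C(F)(F)F)cc2)nn1)c1cn(-c2ccccc2)nc1-c1ccccc1` and compound 2 `COc1ccc(-c2nn(-c3ccccc3)cc2C(=O)NCc2cn(Cc3ccc(Cl)cc3)nn2)cc1` share the amide-linked core but differ in two places, so no single step joins them. In a functional assay on MIA PaCa-2 cells (Homo sapiens) for antiproliferative activity, read by sulforhodamine B assay, with a stated time of 48 h (a lower number here means a stronger inhibitor of growth, a higher number a weaker inhibitor of growth), compound 1 gives 17700 nM. In this assay compound 2 gives 26300 nM. These two numbers lie within the scatter of each other, so compound 2 cannot be set apart from compound 1 on what is known; both sit in the same weak range.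

Compound 3 `COc1ccc(-c2nn(-c3ccccc3)cc2C(=O)NCc2cn(Cc3ccc(C(F)(F)F)cc3)nn2)cc1` is not yet measured. It keeps everything of compound 2 except one change: trifluoromethyl in place of chloro on an aromatic carbon. Compound 1 already carries a trifluoromethyl group on its benzyl ring, with a different other substituent, and its value and that of compound 2 show no separation beyond the scatter. Nothing in the measured pair points to a direction for this exchange. The step from compound 2 to compound 3 in this assay is expected to be a 1.2-fold lower number from compound 2 to compound 3 (0.08 log units; within the scatter), nothing beyond the scatter. For compound 3 the estimate in this assay is 22000 nM, with a range from 9000 nM to 55000 nM.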

Compound 3, concentration for 50% growth inhibition: > 100000 nM
Compound 3: only a limit was reported (the forecaster's own chance of this, stated with the estimate: 10%); middle value at least 4.5-fold (0.65 log units) from the limit.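

In this assay compound 3 stands at a limit of the assay and not at a number: the limit of > 100000 nM in this assay, at which 1 of the 3 values shown sits.

Among these compounds, the 4-chlorobenzyl to 4-(trifluoromethyl)benzyl exchange is therefore not neutral when methoxy is present, with an at least 3.8-fold higher number from compound 2 to compound 3 (0.58 log units; beyond the scatter), the first readable step at this position, and its true size remains open beyond the bound printed. Trifluoromethyl on the benzyl ring is also not enough on its own to account for the result, as methoxy in place of hydrogen on an aromatic carbon, with the trifluoromethyl held in place, gives an at least 5.6-fold higher number from compound 1 to compound 3 (0.75 log units; beyond the scatter), so compound 3, the only compound shown that carries both groups, lies one step from each of compound 1 and compound 2.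

The compounds shown do not tell whether the two changes act independently or only in combination, as no compound pairs chloro on the benzyl ring with hydrogen in place of methoxy. They also leave open how this position responds to a group such as an amine, a carboxylic acid or a longer alkyl chain, and they give no cause for either step.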